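Homoisoflavonoid series: methyl-ether to phenol step

The source may report more compounds than this note shows. Statements on the series, on what has been measured and on what is new or still open speak of the compounds shown alone.

Measured so far:
compound 1, `CN(C)c1ccc(/C=C2\COc3ccccc3C2=O)cc1`, 8510 nM
compound 2, `COc1cc(/C=C2\COc3ccccc3C2=O)ccc1O`, 105000 nM

In an assay on isolated protein for inhibition of Amine oxidase [flavin-containing] B (Homo sapiens) (on this read-out higher numbers stand for weaker inhibition and lower numbers for stronger inhibition), compound 2 gives 105000 nM, the highest of the two numbers; compound 1 gives 8510 nM, a gap beyond the scatter. Compound 3, `O=C1/C(=C/c2ccc(O)c(O)c2)COc2ccccc21`, differs from compound 2 by hydrogen in place of methyl on an oxygen on an aromatic ring. Within the data shown here, no measured pair shows this change, so no step beyond the scatter is assumed in either direction. Compound 3 is expected near 120000 nM, with a range from 40000 nM to 400000 nM. The estimated change is a 1.1-fold higher number from compound 2 to compound 3 (0.06 log units; within the scatter).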

Compound 3, half-maximal inhibitory concentration: 141000 nM
Estimate against measurement, compound 3: 1.2-fold (0.07 log units) below; the range from low to high includes it.
By their numbers in this assay, from the lowest: compound 1; then compounds 2 and 3 (each within the scatter of the next).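

In this assay, among these compounds, the methoxy to hydroxy pair gives a 1.3-fold higher number from compound 2 to compound 3 (0.13 log units; within the scatter) and so offers the first direct reading of this change. At this oxygen on the aromatic ring, methyl and hydrogen cannot be told apart in this assay. No measurement available here explains this result.

As far as these compounds go, whether a longer chain such as ethoxy on this oxygen, or an amine or a carboxylic acid in place of the whole group, would read differently remains open. So does whether methoxy to hydroxy reads the same elsewhere on the shared core.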